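The source may report more compounds than this note shows. Statements on the series, on what has been measured and on what is new or still open speak of the compounds shown alone.

Measured compounds in a functional assay on B16-F10 cells (Mus musculus) for inhibition, read by MTT assay, with a stated time of 72 h; a higher number here means a weaker inhibitor, a lower number a stronger inhibitor:
- compound 1, `CC(C)c1ccc(-c2nc(SCc3cn(CC(=O)NC(=O)Nc4ccccn4)nn3)nc(Nc3ccc(F)cc3)c2C#N)cc1`: 7250 nM
- compound 2, `CC(C)c1ccc(-c2nc(SCc3cn(CC(=O)NC(=O)Nc4ccccn4)nn3)nc(Nc3ccc(Cl)cc3)c2C#N)cc1`: 860 nM
- compound 3, `CC(C)c1ccc(-c2nc(SCc3cn(CC(=O)NC(=O)Nc4ccccn4)nn3)nc(Nc3ccccc3O)c2C#N)cc1`: 16100 nM

Compound 1 holds the second highest of the three numbers. Its nearest neighbour is compound 3, reached by a 2.2-fold higher number from compound 1 to compound 3 (0.35 log units; beyond the scatter); its furthest is compound 2, reached by an 8.4-fold lower number from compound 1 to compound 2 (0.93 log units; beyond the scatter). The step from compound 2 to compound 3 is the largest seen here, a 19-fold higher number from compound 2 to compound 3 (1.27 log units; beyond the scatter).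

The next compound, compound 4, `CC(C)c1ccc(Nc2nc(SCc3cn(CC(=O)NC(=O)Nc4ccccn4)nn3)nc(-c3ccc(C(C)C)cc3)c2C#N)cc1`, has not yet been measured in this assay. It differs from compound 1 in one place: isopropyl in place of fluoro on an aromatic carbon.

For the measured compounds named here, only one measured step bears on this change. In the step from compound 1 to compound 2 the same aromatic carbon is also changed, fluoro giving way to chloro, and the number falls by an 8.4-fold lower number from compound 1 to compound 2 (0.93 log units; beyond the scatter), a modest step beyond the scatter. Going by the values given here, no measured pair puts an isopropyl at that carbon, so the size of the step for compound 4 rests on that single comparison. A lower number than compound 1 is therefore expected, though of uncertain size.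

Compound 4 is estimated to give 2000 nM in this assay, with a range from 500 nM to 8000 nM. This estimate for compound 4 means an expected step of a 3.6-fold lower number from compound 1 to compound 4 (0.56 log units; beyond the scatter).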

Compound 4, half-maximal inhibitory concentration: 4380 nM
Compound 4: middle estimate off by 2.2-fold (0.34 log units), on the low side, within the range that was stated.
By their numbers in this assay, from the lowest: compound 2; then compounds 4 and 1 (each within the scatter of the next); then compound 3.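

In this assay, isopropyl and fluoro on this aromatic carbon cannot be told apart, with a 1.7-fold lower number from compound 1 to compound 4 (0.22 log units; within the scatter), so the drop seen with chloro does not extend to this larger group, and chloro stands clear of isopropyl in a 5.1-fold higher number from compound 2 to compound 4 (0.71 log units; beyond the scatter). At this position, then, the number does not follow the count of heavy atoms in the group among the three compounds that vary there, since compound 2 differs from both compound 1 and compound 4 while those two stay within the scatter of each other; the 4-isopropylphenyl group on the nitrogen also stands apart from 2-hydroxyphenyl, with a 3.7-fold lower number from compound 3 to compound 4 (0.57 log units; beyond the scatter). No evidence accompanies these values that could explain the differences between the groups.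

The compounds shown leave open whether the low number of compound 2 belongs to chloro alone or would also appear with bromo, methyl or methoxy on this aromatic carbon. They also leave open how a hydroxy group, an amine or a carboxylic acid on this same carbon would read against the 2-hydroxyphenyl of compound 3.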